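The source may report more compounds than this note shows. Statements on the series, on what has been measured and on what is new or still open speak of the compounds shown alone.

Compound 1 `COc1cc(-c2nnc3n2NC(c2cccs2)C(C(=O)c2ccccc2)S3)cc(OC)c1OC` — in a functional assay on HepG2 cells (Homo sapiens) for cytotoxicity, read by MTT assay, with a stated time of 48 h (a lower number here means a stronger inhibitor, a higher number a weaker inhibitor), compound 1 gives > 100000 nM, which is a limit of the assay and not a number.
Compound 2 `COc1cc(-c2nnc3n2NC(c2cccs2)C(C(=O)c2ccc(F)cc2)S3)cc(OC)c1OC` — compound 2 gives 54200 nM.
Compound 3 `COc1cc(-c2nnc3n2NC(c2ccco2)C(C(=O)c2ccccc2)S3)cc(OC)c1OC` — compound 3 gives 90900 nM.

Compound 3 and compound 2 sit within the scatter of each other, so no order between them can be read; compound 1 contributes only a limit (the limit of > 100000 nM in this assay, at which 1 of the 3 values shown sits). Compound 4 `COc1cccc(C(=O)C2Sc3nnc(-c4cc(OC)c(OC)c(OC)c4)n3NC2c2ccco2)c1` differs from compound 3 by methoxy in place of hydrogen on an aromatic carbon. Among the compounds with values here, no measured step is the same change. Within the data shown here, the only step on an aromatic carbon of the benzoyl group is an at least 1.8-fold lower number from compound 1 to compound 2 (0.26 log units; that floor lies within the scatter), a floor within the scatter; the other step of an at least 1.1-fold lower number from compound 1 to compound 3 (0.04 log units; that floor lies within the scatter) concerns the saturated ring carbon and is also within the scatter. Neither gives ground to expect a move beyond the scatter for compound 4. The estimated step is therefore a 1.2-fold lower number from compound 3 to compound 4 (0.08 log units; within the scatter). Compound 4 is expected at 75000 nM, with a range of 30000 nM to 160000 nM.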

Compound 4, half-maximal inhibitory concentration: > 100000 nM
Compound 4: a limit, no number; the forecaster's own chance of this, stated with the estimate: 30%; middle value at least 1.3-fold (0.12 log units) from the limit.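

In this assay compound 4 gives > 100000 nM, a limit of the assay and not a number. The step reads an at least 1.1-fold higher number from compound 3 to compound 4 (0.04 log units; that floor lies within the scatter), so benzoyl to (3-methoxyphenyl)carbonyl on the furan-2-yl compound gives no sign of a lower number, though a floor alone cannot fix the size of the change. The limit now recurs among the compounds shown: the limit of > 100000 nM in this assay, at which 2 of the 4 values shown sit.

Where compound 4 truly lies remains open. Also open, from the compounds shown here alone, is whether an amine or a carboxylic acid in place of methoxy on this ring would give a measurable number.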